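This account rests on a few compounds, and the source may have more. Where it says the series, first, only, none or still open, it means among the compounds named here.

Compound 1 `CC(C)CC1n2cncc2CN(Cc2ccc(OC(F)(F)F)cc2)S1(=O)=O`: 0.117 h
Compound 2 `CC(C)CC1n2cncc2CN(Cc2ccc(F)cc2)S1(=O)=O`: 0.0833 h
Compound 3 `COC(C)(C)CC1n2cncc2CN([C@@H](C)c2ccc(Cl)cc2)S1(=O)=O`: 0.2 h

In an in vitro ADME assay on microsomes from liver (Homo sapiens) for metabolic stability (on this read-out lower numbers stand for a shorter-lived compound and higher numbers for a longer-lived compound), the three measured compounds all give short half-lives. Compound 3 has the largest of the three figures, but its gap from compound 1 lies within the usual scatter, so the two cannot be ranked; only its gap from compound 2 lies beyond the scatter. Among the compounds with values here, the one measured step between neighbours, a 1.4-fold lower number from compound 1 to compound 2 (0.15 log units; within the scatter), is small and concerns a substituent on an aromatic ring.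

Compound 4 `C[C@@H](c1ccc(Cl)cc1)N1Cc2cncn2C(C[C@@H](O)c2ccccc2)S1(=O)=O` differs from compound 3 at a different place: hydroxy(phenyl)methyl in place of 1-methoxy-1-methylethyl on a saturated chain carbon bound to a saturated ring carbon. Within the data shown here, no measured step touches this part of the shared core, so the single step at hand gives no direct guide, and the three values themselves span only a narrow band. The reasonable expectation is therefore that compound 4 stays near compound 3, with an estimated step of no change at the digits printed from compound 3 to compound 4 (within the scatter) that does not clearly leave the scatter. Compound 4 is estimated at 0.2 h in this assay, within a range from 0.08 h to 0.5 h.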

Compound 4, half-life: 0.4 h
For compound 4 the middle estimate is 2.0-fold (0.30 log units) below the measured one; measured number inside the range.
By their numbers in this assay, from the lowest: compounds 2, 1, 3 and 4 (each within the scatter of the next, the first and the last beyond it).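

Within the data shown here, this is the first measured change at this place, on a saturated chain carbon bound to a saturated ring carbon, and in this assay it reads a 2.0-fold higher number from compound 3 to compound 4 (0.30 log units; within the scatter), a step that stays inside the normal spread of repeat measurements. A larger group, bringing a six-membered aromatic ring and a hydrogen-bond donor, can therefore stand here with no clear loss of half-life, though no gain can be claimed either. Nothing shown offers a measured explanation for this result.

As far as these compounds go, the hydroxy and the phenyl ring enter together, so what each contributes on its own stays unknown. A 2-phenylethyl group without the hydroxy would separate the two, while an amine in place of the hydroxy remains a further open question.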